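Adding a Third Methoxy to a Strongly Cytotoxic Chalcone

The source may hold more compounds than are shown below. What is called first, only, known or untested is meant among the compounds shown, and "the series" means these compounds.

Compound 1 `COc1ccc(C(=O)/C=C/c2cc(-c3cc(OC)c(OC)c(OC)c3)n[nH]2)cc1OC` gives -99% in a functional assay on U-251 cells (Homo sapiens) for cytotoxicity, read by sulforhodamine B assay, with a stated time of 48 h, tested at 100 uM (on this read-out lower numbers stand for a stronger effect and higher numbers for a weaker effect at the one concentration tested), the lowest of the three numbers measured. Compound 2 `COc1ccc(C(=O)/C=C/c2cc(-c3cc(OC)c(OC)c(OC)c3)n[nH]2)cc1` gives -25% and compound 3 `COc1cc(-c2cc(/C=C/C(=O)c3ccc(F)c(F)c3)[nH]n2)cc(OC)c1OC` gives -29%. Compound 4 `COc1cc(C(=O)/C=C/c2cc(-c3cc(OC)c(OC)c(OC)c3)n[nH]2)cc(OC)c1OC` differs from compound 1 by methoxy in place of hydrogen on an aromatic carbon. Within the data shown here, two measured steps touch the same ring of compound 1: a number 74 percentage points higher from compound 1 to compound 2 (beyond the scatter), and a number 70 percentage points higher from compound 1 to compound 3 (beyond the scatter). Both show that changing this ring weakens the effect sharply, but neither adds a group, so the direction for compound 4 is not settled by them. The estimate keeps compound 4 near compound 1, with a wide range toward weaker effect: a number 19 percentage points higher from compound 1 to compound 4 (beyond the scatter). Compound 4 is expected to give -80%, between -100% and -25%.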

Compound 4, a percentage reported as activity, at one concentration (the size of the read-out at that concentration, not a potency): -99%
Estimate against measurement, compound 4: 19 percentage points above; measured number inside the range.
By their numbers in this assay, from the lowest: compounds 1 and 4 (each within the scatter of the next); then compounds 3 and 2 (each within the scatter of the next).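

In this assay, methoxy in place of hydrogen on an aromatic carbon gives no change at the digits printed from compound 1 to compound 4 (within the scatter). The earlier steps shown here on this ring only removed or swapped groups, with results such as a number 74 percentage points higher from compound 1 to compound 2 (beyond the scatter); this step shows that the ring can also carry an added methoxy, ortho to a methoxy group, and keep its effect. No available data explain why the effect holds. Still open, going by these compounds, is whether the same place would keep the effect with a different group, such as an ethoxy, an amine or a carboxylic acid.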